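A few compounds are considered here, and "the series" means these few. Any claim that something is new, unique, unknown or untested is made for them only; others in the source may bear on it.

Compound 1 `C(#Cc1nc2c(s1)CN(C1CCCCC1)CC2)c1ccccc1` and compound 2 `CC(=O)N1CCc2nc(C#Cc3ccccc3)sc2C1` share one core and differ only at the ring amine nitrogen. In an assay on HEK293 cells for positive allosteric modulation of metabotropic glutamate receptor 5 (Homo sapiens), read by FLIPR, with a stated time of 1 h (a lower number here means that less compound is needed, a higher number that more compound is needed for the effect), compound 1 gives only the limit > 10000 nM. Compound 2 likewise gives only the limit > 10000 nM. The step that the two limits leave unreadable from compound 1 to compound 2 therefore cannot be sized, since both values sit at the limit of > 10000 nM in this assay, at which 2 of the 2 values shown sit. Compound 3 `CC1CC1C(=O)N1CCc2nc(C#Cc3ccccc3)sc2C1` arises from compound 2 by 2-methylcyclopropyl in place of methyl on a carbonyl carbon. Among the compounds with values here, no measured step bears on this change, so a step that the limit leaves unreadable from compound 2 to compound 3 is expected to be small, with compound 3 likely again at a limit. Compound 3 is estimated at 12000 nM, between 3000 nM and 40000 nM.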

Compound 3, half-maximal effective concentration: 9.4 nM
For compound 3 the middle estimate is 1300-fold (3.11 log units) above the measured one, outside the stated range (below it).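

With 2-methylcyclopropyl in place of methyl on a carbonyl carbon, this assay shows an at least 1000-fold lower number from compound 2 to compound 3 (3.02 log units; beyond the scatter). Exchanging the whole group on the ring amine nitrogen gives an at least 1000-fold lower number from compound 1 to compound 3 (3.02 log units; beyond the scatter), so the group at this nitrogen can decide whether the shared core gives a readable value at all. Only compound 3 stands clear of the limit in this assay: the limit of > 10000 nM in this assay, at which 2 of the 3 values shown sit.

Whether the ring or its methyl accounts for the step remains open. So does how a plain cyclopropyl or an ethyl chain on the same carbonyl carbon would compare.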